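Shrinking the aryl group on the shared core

The compounds below may be only part of what the source reports. "The series", "measured", "known", "first", "only" and "open" are said of these compounds alone.

Working notes on the series. Compound 2 `COc1cc(-c2ccnc3cc(-c4ccc5ccn(C)c5c4)nn23)cc(OC)c1OC` carries a 1-methyl-1H-indol-6-yl group on the shared core, and in a functional assay on HCT-116 cells (Homo sapiens) for inhibition, read by CCK-8 assay, with a stated time of 48 h (a higher number here means a weaker inhibitor, a lower number a stronger inhibitor), compound 2 gives 1040 nM. Among the compounds with values here, that is the lowest of the two numbers known in this assay; the nearest, compound 3 `COc1cc(-c2ccnc3cc(-c4cn(C(=O)OC(C)(C)C)c5ccccc45)nn23)cc(OC)c1OC`, gives 5720 nM, a gap beyond the usual scatter. Compound 1 `COc1cc(-c2cc3nccc(-c4c[nH]c5ccccc45)n3n2)cc(OC)c1OC` returns only a limit in this assay, namely > 10000 nM. One of the three values shown thus sits at a limit rather than at a number (the limit of > 10000 nM in this assay, at which 1 of the 3 values shown sits).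

Compound 4 `COc1cc(-c2ccnc3cc(-c4cccc(C)c4)nn23)cc(OC)c1OC` has not been measured in this assay. It differs from compound 2 in a single place: 3-methylphenyl in place of 1-methyl-1H-indol-6-yl on an aromatic carbon. Within the data shown here, no pair of measured compounds differs in one place, so this change cannot be read off a known step. The step from compound 2 to compound 4 is expected to run toward a weaker inhibitor, a 2.9-fold higher number from compound 2 to compound 4 (0.46 log units; beyond the scatter), beyond the scatter. For compound 4 the estimate in this assay is 3000 nM, with a range from 1000 nM to 10000 nM.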

Compound 4, half-maximal inhibitory concentration: 6150 nM
Compound 4: middle estimate off by 2.1-fold (0.31 log units), on the low side; low and high end bracket the measured number.
By their numbers in this assay, from the lowest: compound 2; then compounds 3 and 4 (each within the scatter of the next). At a limit, above all of these: compound 1.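

In this assay, within the data shown here, the change gives a 5.9-fold higher number from compound 2 to compound 4 (0.77 log units; beyond the scatter) and is the first single-place step. It shows that this aromatic carbon of the shared core is sensitive to the aryl group it carries: with the two-ring 1-methyl-1H-indol-6-yl group replaced by the one-ring 3-methylphenyl group, the inhibitor is weaker by more than the scatter. Nothing measured here accounts for this step.

The step changes the ring count, the heavy-atom count and the ring nitrogen together, so it cannot say which of these matters. It also leaves open how a phenyl ring carrying a methoxy group or an amine in place of the methyl group, or a bicyclic group with a second ring nitrogen, would read at this carbon.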